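Removing the aromatic methyl from compound 1

The source may hold more compounds than are shown below. What is called first, only, known or untested is meant among the compounds shown, and "the series" means these compounds.

Compound 1 `C#CCN(Cc1cc2c(O)nc(C)nc2cc1C)c1ccc(C(=O)N[C@@H](CCC(=O)O)C(=O)N(C)[C@@H](CCC(=O)O)C(=O)O)c(F)c1` stands second highest of the three numbers in a functional assay for inhibition, with Mus musculus as the target (on this read-out lower numbers stand for stronger inhibition and higher numbers for weaker inhibition), where compound 1 gives 1400 nM. Compound 2 `C#CCN(Cc1cc2c(O)nc(C)nc2cc1C)c1ccc(C(=O)N[C@@H](CCC(=O)O)C(=O)N(CC)[C@@H](CCC(=O)O)C(=O)O)c(F)c1` gives 220 nM, a step of a 6.4-fold lower number from compound 1 to compound 2 (0.80 log units; beyond the scatter). Compound 3 `Cc1nc(O)c2cc(CN(C)c3ccc(C(=O)N[C@@H](CCC(=O)O)C(=O)N(C)[C@@H](CCC(=O)O)C(=O)O)c(F)c3)c(C)cc2n1` gives 2600 nM, a step of a 1.9-fold higher number from compound 1 to compound 3 (0.27 log units; within the scatter). Compound 4 `C#CCN(Cc1ccc2nc(C)nc(O)c2c1)c1ccc(C(=O)N[C@@H](CCC(=O)O)C(=O)N(C)[C@@H](CCC(=O)O)C(=O)O)c(F)c1` is not yet measured; it differs from compound 1 by hydrogen in place of methyl on an aromatic carbon. Among the compounds with values here, neither measured step bears on this change: the one to compound 2 alters a saturated chain carbon bound to an amide-type nitrogen, the one to compound 3 a saturated chain carbon bound to a nitrogen on an aromatic ring, and no measured compound varies the methyl on the aromatic carbon. With nothing to go on, no step beyond the scatter is expected, and for compound 4 the estimated change is no change at the digits printed from compound 1 to compound 4 (within the scatter). Compound 4 is thus expected at 1400 nM, within 500 nM to 4000 nM.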

Compound 4, half-maximal inhibitory concentration: 2600 nM
Beside the measured number, compound 4's estimate is 1.9-fold (0.27 log units) below it; the measured number falls inside the stated range.
By their numbers in this assay, from the lowest: compound 2; then compounds 1, 3 and 4 (each within the scatter of the next).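

In this assay, hydrogen in place of methyl on this aromatic carbon gives a step within the scatter (a 1.9-fold higher number from compound 1 to compound 4 (0.27 log units; within the scatter)), so this methyl, ortho to a large group, is not needed to keep the activity of compound 1. No measured evidence on this position bears on the result.

Open, as far as these compounds go, is whether a methoxy group, a chlorine or an amine on this carbon would give a step beyond the scatter. Also open, from the compounds shown here alone, is whether losing the methyl has as little effect in compound 2, which carries the ethyl group on the amide-type nitrogen.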